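Azetidinyl in place of dimethylamino on a long-chain pyridinol

This account rests on a few compounds, and the source may have more. Where it says the series, first, only, none or still open, it means among the compounds named here.

Compound 1 `CCCCCCCCCCc1nc(N(C)C)c(C)c(C)c1O`: 74%
Compound 2 `CCCCCCCCCCCCCCCCc1nc(N(C)C)c(C)c(C)c1O`: 91%

Going by the values given here, in a functional assay on cells (Lymphocyte, Homo sapiens), read by trypan blue exclusion, with a stated time of 16 h, tested at 0.5 uM (on this read-out lower numbers stand for a weaker effect and higher numbers for a stronger effect at the one concentration tested), compound 2 gives the higher of the two numbers, the only measured step being a number 17 percentage points higher from compound 1 to compound 2 (beyond the scatter). Compound 3 `CCCCCCCCCCCCCCCCc1nc(N2CCC2)c(C)c(C)c1O` keeps that longer chain and changes the amine: azetidin-1-yl in place of dimethylamino on an aromatic carbon. Among the compounds with values here, no measured step touches this group, so the two values say nothing about it directly; the expected change is a number 6 percentage points lower from compound 2 to compound 3 (within the scatter), within the scatter. Compound 3 is therefore estimated at 85%, between 65% and 98%.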

Compound 3, a percentage reported as activity, at one concentration (the size of the read-out at that concentration, not a potency): 70%
Estimate against measurement, compound 3: 15 percentage points above; measured number inside the range.
By their numbers in this assay, from the lowest: compounds 3 and 1 (each within the scatter of the next); then compound 2.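

The amine on this aromatic carbon, next to the ring nitrogen and para to a hydroxy group, is not a silent position in this assay: azetidin-1-yl in place of dimethylamino gives a number 21 percentage points lower from compound 2 to compound 3 (beyond the scatter) on the longer chain. This loss comes with no difference in the counted hydrogen-bond donors or acceptors between the two groups. Nothing available accounts for the step. As far as these compounds go, whether the same change would cost as much on the shorter chain of compound 1 remains open. So does how a pyrrolidine or piperidine would read at this position.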